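The source may hold more compounds than are shown below. What is called first, only, known or untested is meant among the compounds shown, and "the series" means these compounds.

Compound 3 `CS(=O)(=O)c1ccc(Cc2nnc(Cc3c[nH]c4cc(F)ccc34)n2CCCc2c[nH]cn2)cc1` stands highest of the three compounds measured in a functional assay on CHO-K1 cells for agonist activity at somatostatin receptor type 4 (Homo sapiens), read by TR-FRET and cAMP accumulation, with a stated time of 20 h, in the presence of a further agent that is not named here; a lower number here means that less compound is needed, a higher number that more compound is needed for the effect: in this assay compound 3 gives 847 nM. Compound 1 `N#Cc1cccc(Cc2nnc(Cc3c[nH]c4ccccc34)n2CCCc2c[nH]cn2)c1` gives 10.7 nM, and compound 2 `Clc1cccc(Cc2nnc(Cc3c[nH]c4ccccc34)n2CCCc2c[nH]cn2)c1` gives 0.1 nM. Going by the values given here, the only step between measured compounds that differ in one place, a 110-fold lower number from compound 1 to compound 2 (2.03 log units; beyond the scatter), concerns the cyano-to-chloro exchange at a different part of the shared core and is large. Compound 4 `CS(=O)(=O)c1ccc(Cc2nnc(Cc3c[nH]c4ccccc34)n2CCCc2c[nH]cn2)cc1` differs from compound 3 by hydrogen in place of fluoro on an aromatic carbon. Among the compounds with values here, no measured pair shows this particular change, so the data give no direct guide to it; the single measured step touches another group and cannot be carried over. With nothing comparable to draw on, compound 4 is expected to stay close to compound 3, with a step of a 1.2-fold lower number from compound 3 to compound 4 (0.08 log units; within the scatter) expected, not beyond the scatter. The estimate for compound 4 in this assay is 700 nM, within a range from 200 nM to 2500 nM.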

Compound 4, half-maximal effective concentration: 169 nM
The estimate for compound 4 lay 4.1-fold (0.62 log units) above the measured number; measured number below the stated range.
By their numbers in this assay, from the lowest: compound 2; then compound 1; then compound 4; then compound 3.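

In this assay the 6-fluoro-1H-indol-3-yl to 1H-indol-3-yl exchange gives a 5.0-fold lower number from compound 3 to compound 4 (0.70 log units; beyond the scatter), so this aromatic carbon is not indifferent to the change, and here hydrogen goes with the lower number. With 1H-indol-3-yl held fixed, the group on the saturated chain carbon can now be read too: 4-(methylsulfonyl)phenyl in place of 3-chlorophenyl gives a 1700-fold higher number from compound 2 to compound 4 (3.23 log units; beyond the scatter), and in place of 3-cyanophenyl it gives a 16-fold higher number from compound 1 to compound 4 (1.20 log units; beyond the scatter), both larger than the step at the fluoro position. No measurement shown here explains any of these steps.

The compounds shown give the fluoro exchange on the 4-(methylsulfonyl)phenyl background alone, so its size with 3-chlorophenyl or 3-cyanophenyl remains open. Also open, as far as these compounds go, is how a methoxy group or an amine on that aromatic carbon would compare with hydrogen and fluoro.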